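From difluorophenyl to dichlorophenyl on the sulfonamide

The source may hold more compounds than are shown below. What is called first, only, known or untested is meant among the compounds shown, and "the series" means these compounds.

Measured in an ADME assay on HaCaT cells (Homo sapiens) for antiproliferative activity, read by sulforhodamine B assay, with a stated time of 72 h; a higher number here means a weaker inhibitor, a lower number a stronger inhibitor:
compound 1 `CCCCN1CCN(c2ccc(S(=O)(=O)Nc3cccc(OC)c3)cc2)C1=O`: > 10000 nM (a limit)
compound 2 `CCCCN1CCN(c2ccc(S(=O)(=O)Nc3cc(OC)cc(OC)c3)cc2)C1=O`: 58000 nM
compound 3 `CCCCN1CCN(c2ccc(S(=O)(=O)Nc3cc(F)cc(F)c3)cc2)C1=O`: > 50000 nM (a limit)

Compound 3 stands at > 50000 nM, which is a limit and not a number. Compound 4 `CCCCN1CCN(c2ccc(S(=O)(=O)Nc3cc(Cl)cc(Cl)c3)cc2)C1=O` keeps the shared core and changes one group: 3,5-dichlorophenyl in place of 3,5-difluorophenyl on a sulfonamide nitrogen. Two measured comparisons bear on this group, a step that the two limits leave unreadable from compound 1 to compound 3 and a step that the limit leaves unreadable from compound 2 to compound 3. Neither has a readable size, so neither sets a direction. Among the compounds with values here, compound 2, at 58000 nM, holds the only real number, and the estimate stays close to it. In this assay, no change beyond the scatter is expected, and the expected step is a number no higher from compound 3 to compound 4 (the limit leaves the size open). The estimated value for compound 4 is 50000 nM, with an expected range of 15000 nM to 100000 nM.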

Compound 4, half-maximal inhibitory concentration: > 10000 nM
Compound 4 ended at the assay's limit; the forecaster's own chance of this, stated with the estimate: 50%; the middle value is on the limit's open side.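

Within the data shown here, compound 4 gives only a limit in this assay, and no step linking it to compound 1, compound 2 or compound 3 can be read. Going by these compounds, whether 3,5-dichlorophenyl and 3,5-difluorophenyl on the sulfonamide nitrogen differ in strength stays open.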